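This account rests on a few compounds, and the source may have more. Where it says the series, first, only, none or still open, it means among the compounds named here.

Compound 1, with the structure `O=C(COc1cccc2ccccc12)N/N=C/c1ccc(O)cc1`, and compound 2, with the structure `C/C(=N\NC(=O)COc1cccc2ccccc12)c1ccc(C#N)cc1Br`, share a core built around a naphthyloxy-acetyl hydrazone, and both have been tested for how much of the substance is needed before cultured human cells start to suffer. In an ADME assay on HEL cells (Homo sapiens) for cytotoxicity (on this read-out higher numbers stand for lower toxicity in this test and lower numbers for higher toxicity in this test), compound 1 gives 20 ug/mL, and in the same test compound 2 gives 20 ug/mL. These two numbers are level with each other at the digits shown, so the pair offers no measured step in either direction, only a shared level.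

Compound 3, with the structure `O=C(COc1cccc2ccccc12)N/N=C/c1ccc(Br)cc1`, is the next member. It differs from compound 1 in a single place: bromo in place of hydroxy on an aromatic carbon. For the measured compounds named here, with only one level available and no measured step, the simplest expectation is that compound 3 in this assay will sit close to that level, and the step from compound 1 to compound 3 is expected to be no change at the digits printed from compound 1 to compound 3 (within the scatter), within the usual scatter rather than beyond it. Compound 3 is therefore estimated at 20 ug/mL, with a likely range from 10 ug/mL to 45 ug/mL.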

Compound 3, minimum cytotoxic concentration: > 100 ug/mL
Compound 3 gave a limit, no number (the forecaster's own chance of this, stated with the estimate: 20%); middle value at least 5.0-fold (0.69 log units) from the limit.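

In this assay, for the compounds shown here, the change of 4-hydroxyphenyl to 4-bromophenyl gives an at least 5.0-fold higher number from compound 1 to compound 3 (0.69 log units; beyond the scatter), a step beyond the scatter towards lower toxicity in this test, whereas the earlier compounds offered only a shared level and no step at all. Going by these compounds alone, this is the first sign that the group on this aromatic carbon, para to a large group, can move the read-out, even though only one heavy atom is exchanged and the rest of the molecule stays the same. The reading for compound 3 is a limit of the assay and not a number, so the step has a known minimum but no known full size: the limit of > 100 ug/mL in this assay, at which 1 of the 3 values shown sits.

Hydroxy brings one hydrogen-bond donor and one hydrogen-bond acceptor and bromo brings neither, but a single pair cannot separate the loss of hydroxy from the arrival of bromine as the source of the step. Going by these compounds, whether an amine, a methoxy group or a chlorine at the same place would stay near compound 1 or move with compound 3 remains open.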